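Halogen swap on the benzylidene arm of the shared core

The source may report more compounds than this note shows. Statements on the series, on what has been measured and on what is new or still open speak of the compounds shown alone.

Compound 2 `C=CCn1c(=O)/c(=C\c2ccccc2F)[nH]c(=O)/c1=C\c1ccccc1OC` is the starting point. In a functional assay on NCI-H1975 cells (Homo sapiens) for cytotoxicity, read by CCK-8 assay, with a stated time of 72 h (a lower number here means a stronger inhibitor, a higher number a weaker inhibitor), compound 2 gives 25100 nM. Its nearest neighbour is compound 1 `C=CCn1c(=O)/c(=C\c2cccc(F)c2)[nH]c(=O)/c1=C\c1ccccc1OC`, which in this assay gives 25600 nM; the step of a 1.0-fold lower number from compound 1 to compound 2 (0.01 log units; within the scatter) leaves the two indistinguishable, so compound 2 stands alongside compound 1 rather than apart from it. The third entry, compound 3 `C=CCn1c(=O)/c(=C\c2cc(OC)c(OC)c(OC)c2)[nH]c(=O)/c1=C\c1cccc(Br)c1`, carries a different pair of aryl groups and in this assay is recorded as "not active" (no number reported), with no number to place it against the other two.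

Among the measured compounds shown here, the step to compound 4 `C=CCn1c(=O)/c(=C\c2cccc(Cl)c2Cl)[nH]c(=O)/c1=C\c1ccccc1OC` changes only the aryl group on the same arm that the one measured step concerns: 2,3-dichlorophenyl in place of 2-fluorophenyl on a double-bonded chain carbon bound to an aromatic carbon. That measured step, a 1.0-fold lower number from compound 1 to compound 2 (0.01 log units; within the scatter), moved a single halogen between two positions on the ring and stayed within the scatter. For the measured compounds named here, no step exchanges one halogen for another, and none adds a second halogen to this ring, so the data give no direction for the present change. The expectation is therefore a step of a 1.0-fold lower number from compound 2 to compound 4 (0.00 log units; within the scatter), that is, nothing beyond the scatter, with the range widened for the untested halogen pattern.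

Compound 4 is estimated in this assay at 25000 nM, between 9000 nM and 70000 nM.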

Compound 4, half-maximal inhibitory concentration: 4500 nM
For compound 4 the middle estimate is 5.6-fold (0.74 log units) above the measured one; the measured number lies below the stated range.
By their numbers in this assay, from the lowest: compound 4; then compounds 2 and 1 (each within the scatter of the next).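

In this assay the aryl group on this double-bonded chain carbon turns out to matter: 2,3-dichlorophenyl in place of 2-fluorophenyl gives a 5.6-fold lower number from compound 2 to compound 4 (0.75 log units; beyond the scatter) and 2,3-dichlorophenyl in place of 3-fluorophenyl gives a 5.7-fold lower number from compound 1 to compound 4 (0.76 log units; beyond the scatter), both beyond the scatter, whereas the earlier shift of the lone fluorine gave only a 1.0-fold lower number from compound 1 to compound 2 (0.01 log units; within the scatter) and stayed within it. Among the compounds shown here, the position therefore responds to what the ring carries, even though the one earlier step, which only moved a single halogen around the ring, showed no response. The change exchanges the halogen and raises the halogen count in one step, so the two cannot be separated here, and no supporting data on the series offer an explanation for the step.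

Open, going by these compounds, is whether a 2-chlorophenyl or 3-chlorophenyl group alone would carry the same step, or whether both chlorines are needed. Equally open, on these data alone, is whether non-halogen groups on this ring, such as methyl, trifluoromethyl or nitrile, would follow the dichloro compound or the two fluoro compounds.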